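Replacing the Azepine Amide by an Isopropyl(phenyl)amide

A few compounds are considered here, and "the series" means these few. Any claim that something is new, unique, unknown or untested is made for them only; others in the source may bear on it.

Measured so far:
compound 1 `COc1ccc(N(C(=O)CN2C=CN(Cc3ccccc3)C(=O)C(Cc3n[nH]c4ccccc34)C2=O)C(C)C)cc1` gives 31600 nM; > 30000 nM (2 entries) in a functional assay on CHO cells for agonist activity at Melanocortin receptor 4 (Homo sapiens), read by a luciferase reporter, with a stated time of 4 h; on this read-out higher numbers stand for an effect only at larger amounts of compound and lower numbers for an effect already at smaller amounts.
compound 2 `O=C1C(Cc2n[nH]c3cc(F)ccc23)C(=O)N(c2ccccc2)C=CN1CC(=O)N1CCCCc2ccccc21` gives 437 nM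
compound 3 `O=C1C(Cc2n[nH]c3ccccc23)C(=O)N(c2ccccc2)C=CN1CC(=O)N1CCCCc2ccccc21` gives 324 nM

Compound 2 stands at the highest of the two plain numbers, with compound 3 nearest; the step of a 1.3-fold lower number from compound 2 to compound 3 (0.13 log units; within the scatter) shows hydrogen in place of fluoro on an aromatic carbon.

Compound 4 `CC(C)N(C(=O)CN1C=CN(c2ccccc2)C(=O)C(Cc2n[nH]c3cc(F)ccc23)C1=O)c1ccccc1` differs from compound 2 in the amide: a group of 10 heavy atoms (9 carbon, 1 nitrogen; one six-membered aromatic ring of carbon only) in place of a group of 11 heavy atoms (10 carbon, 1 nitrogen; one six-membered aromatic ring of carbon only, one seven-membered non-aromatic ring with 1 hetero atom), on a carbonyl carbon. For the measured compounds named here, no measured step isolates this change. Compound 1 carries a related isopropyl(aryl)amide, yet it also differs elsewhere, so its weak result is only indirect. Compound 4 is therefore expected to lose ground, by a 5.7-fold higher number from compound 2 to compound 4 (0.76 log units; beyond the scatter), with an estimate of 2500 nM and a range of 500 nM to 15000 nM.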

Compound 4, half-maximal effective concentration: 537 nM
The estimate for compound 4 lay 4.7-fold (0.67 log units) above the measured number; low and high end bracket the measured number.
By their numbers in this assay, from the lowest: compounds 3, 2 and 4 (each within the scatter of the next).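

In this assay, putting isopropyl(phenyl)amino in place of the amine with the seven-membered non-aromatic ring, on this carbonyl carbon, gives a 1.2-fold higher number from compound 2 to compound 4 (0.09 log units; within the scatter), so the two amides are not told apart and that seven-membered ring is not needed for a value in this range. Compound 1 carries a related amide but differs elsewhere as well, so its entries say little about this single change. Nothing shown gives a reason for this result. From the compounds shown here alone, whether dimethylamino, or a longer chain in place of isopropyl, would fare alike remains open. So does whether compounds 2 and 4 would still match with hydrogen in place of fluoro.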